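A few compounds are considered here, and "the series" means these few. Any claim that something is new, unique, unknown or untested is made for them only; others in the source may bear on it.

Compound 2 `COc1ccc(-c2cc(/C=C/C(=O)c3ccc(N)cc3)[nH]n2)cc1OC` gives 98% in a functional assay on MDA-MB-231 cells (Homo sapiens) for cytotoxicity, read by sulforhodamine B assay, with a stated time of 48 h, tested at 1 uM; on this read-out lower numbers stand for a stronger effect and higher numbers for a weaker effect at the one concentration tested. Compound 1 `COc1ccc(-c2cc(/C=C/C(=O)c3ccc(N)cc3)[nH]n2)cc1` differs from it by one change, (hydrogen in place of methoxy on an aromatic carbon), and in this assay compound 1 gives 78%, a step of a number 20 percentage points lower from compound 2 to compound 1 (beyond the scatter). Compound 3 `COc1cc(C(=O)/C=C/c2cc(-c3cc(OC)c(OC)c(OC)c3)n[nH]2)cc(OC)c1OC` is built on a different core; the difference between the two cores is not broken down here. In this assay compound 3 gives 73%. Compound 4 `COc1ccc(-c2cc(/C=C/C(=O)c3cc(OC)c(OC)c(OC)c3)[nH]n2)cc1OC` has not yet been measured; it differs from compound 3 by hydrogen in place of methoxy on an aromatic carbon. Within the data shown here, this is the same kind of change as the one from compound 2 to compound 1, though here the place is also meta to a methoxy group. Since the earlier change produced a number 20 percentage points lower from compound 2 to compound 1 (beyond the scatter), a step in the same direction is expected here, a number 15 percentage points lower from compound 3 to compound 4 (beyond the scatter). Compound 4 is therefore estimated at 58%, with a likely range from 40% to 78%.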

Compound 4, a percentage reported as activity, at one concentration (the size of the read-out at that concentration, not a potency): 67%
Beside the measured number, compound 4's estimate is 9 percentage points below it; the measured number falls inside the stated range.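

In this assay, putting hydrogen in place of methoxy gives a number 6 percentage points lower from compound 3 to compound 4 (within the scatter), so on this core the effect of the change cannot be told apart from ordinary variation between repeats. Set beside the earlier case, the two steps do not differ by more than that variation allows: the same change on two cores in this assay, a number 20 percentage points lower (beyond the scatter) from compound 2 to compound 1 and a number 6 percentage points lower (within the scatter) from compound 3 to compound 4, 14 percentage points apart, within the scatter of two such steps The two pairs are therefore compatible with the change carrying over from one core to the other, but two pairs cannot prove that it does, nor explain why only one step lies beyond the scatter.

From the compounds shown here alone, it remains open whether a hydroxyl group or a chlorine atom on that aromatic carbon would behave as hydrogen does here. Each number also comes from one concentration, so it tells only of a stronger or weaker effect at that concentration.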